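This account rests on a few compounds, and the source may have more. Where it says the series, first, only, none or still open, it means among the compounds named here.

Measured compounds in a functional assay on the whole organism (Abdomen, strain Swiss) for inhibition, with Mus musculus as the target, with a stated time of 30 min, at a dose of 10 mg/kg by the intraperitoneal route; a lower number here means less inhibition, a higher number more inhibition at the dose given (going by the name of the read-out):
Compound 1, `COc1ccc(/C=C/C(=O)c2ccc(NC(=S)Nc3ccc(Cl)cc3)cc2)cc1`, gives 92%.
Compound 2, `Cc1ccc(/C=C/C(=O)c2ccc(NC(=O)Nc3ccc(Cl)cc3)cc2)cc1`, gives 42.8%.

Of the two numbers, compound 2 stands lowest. Its nearest neighbour is compound 1, whose read-out in this assay sits well above that of compound 2, a gap that lies beyond the usual scatter of this kind of measurement. Going by the values given here, compound 1 and compound 2 differ in more than one place, so no single step between them can be described; only their two values are known.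

Compound 3, `O=C(Nc1ccc(Cl)cc1)Nc1ccc(C(=O)/C=C/c2ccc(Cl)c(Cl)c2)cc1`, has not yet been measured in this assay. It differs from compound 2 in one place: 3,4-dichlorophenyl in place of 4-methylphenyl on a double-bonded chain carbon bound to a double-bonded chain carbon. Among the compounds with values here, no measured pair in this set isolates this change, so nothing in the data fixes its direction or size. The account therefore expects a step from compound 2 to compound 3 of a number 7.2 percentage points higher from compound 2 to compound 3 (within the scatter), which is small and within the scatter of the assay. On that basis compound 3 is estimated to give 50% in this assay, with a range from 25% to 75%.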

Compound 3, a percentage reported as inhibition, in the whole organism at one dose (the size of the read-out at that dose, not a potency): 21.6%
For compound 3 the middle estimate is 28.4 percentage points above the measured one; the whole stated range lies above it.
By their numbers in this assay, from the lowest: compound 3; then compound 2; then compound 1.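

In this assay, putting 3,4-dichlorophenyl in place of 4-methylphenyl on a double-bonded chain carbon bound to a double-bonded chain carbon gives a number 21.2 percentage points lower from compound 2 to compound 3 (beyond the scatter). Going by these compounds alone, this is the first comparison in the set that isolates a single place, and it shows that the read-out responds to the group at this position, with 4-methylphenyl the better of the two groups tested there on the shared core. No available measurement explains the drop.

Going by these compounds, compound 1 differs from both compound 2 and compound 3 in more than one place, so its value cannot be tied to this position, and whether the same change would lower the read-out on the core of compound 1 remains open. Within the data shown here, with only two groups compared at this place, it also remains open how a plain phenyl, or a phenyl bearing an amine or a carboxylic acid, would compare, and whether the step depends on the two chlorine atoms together or on just one of them.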